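The source may hold more compounds than are shown below. What is called first, only, known or untested is meant among the compounds shown, and "the series" means these compounds.

Measured so far:
compound 1, `OCc1ccc(-c2nn(Cc3c(F)cccc3F)c3ccccc23)o1`, 15000 nM;
compound 2, `OCc1ccc(-c2nn(Cc3ccccc3F)c3cccnc23)o1`, 20400 nM;
compound 3, `Fc1ccccc1Cn1nc(-c2cc[nH]n2)c2cccnc21`, 1800 nM.

In a functional assay (aorta) with Oryctolagus cuniculus as the target (a higher number here means a weaker inhibitor, a lower number a stronger inhibitor), compound 3 gives the lowest of the three numbers. Compound 1 stands away in the weaker direction by a gap beyond the scatter, and compound 2 lies further still; compound 3 is therefore the strongest inhibitor of the three. Among the compounds with values here, no single-change step between measured compounds is available, so the weight of the headgroup on this core cannot be read from a measured pair.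

Compound 4, `Nc1nc(-c2nn(Cc3ccccc3F)c3ncccc23)ncc1F`, departs from compound 3 in one place: 4-amino-5-fluoropyrimidin-2-yl in place of 1H-pyrazol-3-yl on an aromatic carbon. The group that enters carries more hydrogen-bond acceptors than the one that leaves, and the one donor is kept. Within the data shown here, with no measured step to lean on, the direction is uncertain; a change beyond the scatter in either direction is plausible. It is expected that compound 4 improves modestly on compound 3, by a 3.6-fold lower number from compound 3 to compound 4 (0.56 log units; beyond the scatter). Compound 4 is estimated at 500 nM, in the range 100 nM to 3000 nM.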

Compound 4, half-maximal inhibitory concentration: 478000 nM
Estimate against measurement, compound 4: 960-fold (2.98 log units) below, outside the stated range (above it).
By their numbers in this assay, from the lowest: compound 3; then compounds 1 and 2 (each within the scatter of the next); then compound 4.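

In this assay, this position proves highly sensitive to the group it carries: 4-amino-5-fluoropyrimidin-2-yl in place of 1H-pyrazol-3-yl gives a 270-fold higher number from compound 3 to compound 4 (2.42 log units; beyond the scatter). Within the data shown here, this is the only measured single-place step in the set, and it shows that keeping the one hydrogen-bond donor does not preserve the activity when a six-membered aromatic ring with more heavy atoms and more hydrogen-bond acceptors enters. Nothing available bears on the reason for this large loss.

The entering group differs from the leaving one in ring size, amino group and fluorine together, so the compounds shown do not separate the contributions of these features. They also leave open how a plain pyrimidin-2-yl, a 4-aminopyrimidin-2-yl or a carboxylic acid would behave on this aromatic carbon.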